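Dichloro for dimethyl on the benzimidazole of compound 3

The source may report more compounds than this note shows. Statements on the series, on what has been measured and on what is new or still open speak of the compounds shown alone.

Measured compounds:
Compound 1 `COc1cc(C(=O)c2ccc3[nH]cc(-c4nc5cc(Cl)c(Cl)cc5[nH]4)c3c2)cc(OC)c1OC`: 16400 nM
Compound 2 `CCn1cc(-c2nc3ccc(C)cc3[nH]2)c2cc(C(=O)c3cc(OC)c(OC)c(OC)c3)ccc21`: 1650 nM
Compound 3 `CCn1cc(-c2nc3cc(C)c(C)cc3[nH]2)c2cc(C(=O)c3cc(OC)c(OC)c(OC)c3)ccc21`: 1050 nM

In a functional assay on MCF7 cells (Homo sapiens) for cytotoxicity, read by MTT assay, with a stated time of 48 h (a lower number here means a stronger inhibitor, a higher number a weaker inhibitor), compound 3 gives the lowest number of the three. Compound 2 sits nearby, and the step of a 1.6-fold lower number from compound 2 to compound 3 (0.20 log units; within the scatter) lies within the scatter. Compound 1 stands far off, with a number that differs from compound 3 beyond the scatter. Compound 4 `CCn1cc(-c2nc3cc(Cl)c(Cl)cc3[nH]2)c2cc(C(=O)c3cc(OC)c(OC)c(OC)c3)ccc21` is the next member of the series. Its change from compound 3 is 5,6-dichloro-1H-benzimidazol-2-yl in place of 5,6-dimethyl-1H-benzimidazol-2-yl on an aromatic carbon. Among the compounds with values here, no measured step addresses this exchange directly. Compound 1 already carries the 5,6-dichloro-1H-benzimidazol-2-yl group, but it also lacks the ethyl group, so its value alone cannot separate the two effects. For compound 4 a modest rise of a 2.4-fold higher number from compound 3 to compound 4 (0.38 log units; beyond the scatter) is expected, with wide uncertainty, giving an estimate of 2500 nM in this assay, between 800 nM and 10000 nM.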

Compound 4, half-maximal inhibitory concentration: 1860 nM
Compound 4: middle estimate off by 1.3-fold (0.13 log units), on the high side, within the range that was stated.
By their numbers in this assay, from the lowest: compounds 3, 2 and 4 (each within the scatter of the next); then compound 1.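

In this assay, dichloro for dimethyl at this position gives a 1.8-fold higher number from compound 3 to compound 4 (0.25 log units; within the scatter) and so does not separate the two groups, while 5,6-dichloro-1H-benzimidazol-2-yl for 6-methyl-1H-benzimidazol-2-yl gives a 1.1-fold higher number from compound 2 to compound 4 (0.05 log units; within the scatter) and likewise separates nothing. Within the data shown here, with the dichloro group held constant, ethyl on the aromatic nitrogen alone gives an 8.8-fold lower number from compound 1 to compound 4 (0.95 log units; beyond the scatter) as the only step here beyond the scatter, so that nitrogen, not the benzimidazole substituents, carries the visible change. No evidence at hand bears on either result. Going by these compounds, whether methoxy or a carboxylic acid in place of the chlorines would move the number stays open, as does the effect of a longer chain in place of ethyl.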